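The source may hold more compounds than are shown below. What is called first, only, known or untested is meant among the compounds shown, and "the series" means these compounds.

Compound 1 `COc1ccc(Sc2ccccc2N2CC(C)N(CC(=O)O)CC2C)cc1` gives 580 nM in an assay for inhibition of sodium- and chloride-dependent glycine transporter 1 (Homo sapiens); a lower number here means a stronger inhibitor, a higher number a weaker inhibitor. Compound 2 `COc1ccc(Sc2ccc(C)cc2N2CCN(CC(=O)O)C(C)C2)cc1` gives 1600 nM in this assay, and compound 3 `COc1ccc(Sc2ccc(OC)cc2N2CCN(CC(=O)O)C(C)C2)cc1` gives 4600 nM in this assay. The difference between the core of compound 1 and the core of compound 3 is not broken down here. Between compound 3 and compound 2 the change is methyl in place of methoxy on an aromatic carbon, and it brought a 2.9-fold lower number from compound 3 to compound 2 (0.46 log units; beyond the scatter). Compound 4 `Cc1ccc(Sc2ccccc2N2CC(C)N(CC(=O)O)CC2C)cc1` has not yet been measured; it differs from compound 1 by methyl in place of methoxy on an aromatic carbon. This is the same kind of change, not the same one: in compound 4 the group sits para to a large group, whereas in compound 2 it sits meta to a large group and para to a (4-methoxyphenyl)sulfanyl group. Resting on the step of a 2.9-fold lower number from compound 3 to compound 2 (0.46 log units; beyond the scatter), a somewhat smaller move is expected, namely a 1.9-fold lower number from compound 1 to compound 4 (0.29 log units; within the scatter), since the surroundings of the place differ. The estimate for compound 4 in this assay is 300 nM, expected to lie between 120 nM and 900 nM.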

Compound 4, half-maximal inhibitory concentration: 550 nM
Beside the measured number, compound 4's estimate is 1.8-fold (0.26 log units) below it, within the range that was stated.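

On the core of compound 1, the swap of (4-methoxyphenyl)sulfanyl for (4-methylphenyl)sulfanyl brought a 1.1-fold lower number from compound 1 to compound 4 (0.02 log units; within the scatter), so the two compounds cannot be told apart in this assay. The size of the step seen on the other core therefore did not carry over: the same change on two cores in this assay, a 2.9-fold lower number (0.46 log units; beyond the scatter) from compound 3 to compound 2 and a 1.1-fold lower number (0.02 log units; within the scatter) from compound 1 to compound 4, 2.7-fold (0.44 log units) apart, beyond the scatter of two such steps This shows that a step for methyl in place of methoxy cannot simply be transferred between these cores, but with one pair on each it does not show which difference between the pairs sets the size of the step.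

Still open, as far as these compounds go, is whether chlorine or trifluoromethyl in place of the methyl would read alike on both cores. Also open, from the compounds shown here alone, is how an amide in place of the carboxylic acid would fare in this assay.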